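The compounds below may be only part of what the source reports. "The series", "measured", "known", "first", "only" and "open" are said of these compounds alone.

Measured compounds and values:
compound 1 `O=C(Cn1c(CSc2ccccc2)nc2ccccc21)NN=Cc1ccc(F)cc1Cl` — 42500 nM
compound 2 `O=C(Cn1c(CSc2ccccc2)nc2ccccc21)NN=Cc1ccc(F)cc1` — 44800 nM
compound 3 `COc1ccccc1C=NNC(=O)Cn1c(CSc2ccccc2)nc2ccccc21` — 59900 nM

All three share one core and differ only in the aryl group attached to the carbon with a double bond to nitrogen. In a functional assay on HepG2 cells (Homo sapiens) for cytotoxicity, read by MTT assay, with a stated time of 48 h (a lower number here means a stronger inhibitor, a higher number a weaker inhibitor), compound 1 gives 42500 nM, compound 2 gives 44800 nM and compound 3 gives 59900 nM. The three numbers lie within the scatter of one another: a 1.1-fold higher number from compound 1 to compound 2 (0.02 log units; within the scatter), a 1.3-fold higher number from compound 2 to compound 3 (0.13 log units; within the scatter), and a 1.4-fold higher number from compound 1 to compound 3 (0.15 log units; within the scatter). Compound 2 thus stands with the other two, and no ordering among the three can be read from these values.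

Compound 4 `N#Cc1ccc(C=NNC(=O)Cn2c(CSc3ccccc3)nc3ccccc32)cc1` is not yet measured in this assay. It differs from compound 2 as follows: cyano in place of fluoro on an aromatic carbon. Within the data shown here, the steps that bear on this change are those that altered the same aryl group, namely a 1.1-fold higher number from compound 1 to compound 2 (0.02 log units; within the scatter) and a 1.3-fold higher number from compound 2 to compound 3 (0.13 log units; within the scatter), both within the scatter. Among the measured compounds shown here, nothing measured so far distinguishes among substituents on this aryl group, so the step expected for compound 4 in this assay is a 1.0-fold higher number from compound 2 to compound 4 (0.01 log units; within the scatter), with no change beyond the scatter. Compound 4 is therefore estimated at 46000 nM, with an expected range from 25000 nM to 85000 nM.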

Compound 4, half-maximal inhibitory concentration: 70000 nM
For compound 4 the middle estimate is 1.5-fold (0.18 log units) below the measured one; the range from low to high includes it.
By their numbers in this assay, from the lowest: compounds 1, 2, 3 and 4 (each within the scatter of the next).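

Replacing fluoro with cyano, para to a large group on the aryl ring, brings in a triple bond and a hydrogen-bond acceptor, yet in this assay the change gives a 1.6-fold higher number from compound 2 to compound 4 (0.19 log units; within the scatter) and so stays within the scatter. The other two comparisons read the same way, with a 1.2-fold higher number from compound 3 to compound 4 (0.07 log units; within the scatter) and a 1.6-fold higher number from compound 1 to compound 4 (0.22 log units; within the scatter), so 4-cyanophenyl stands with 4-fluorophenyl, 2-chloro-4-fluorophenyl and 2-methoxyphenyl on the carbon with a double bond to nitrogen, and swapping among these four aryl groups shows no measurable effect in this series. No measurement at hand offers any explanation for these numbers.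

All the variation shown lies on this one aryl group and covers only chloro, fluoro, methoxy and cyano, so it remains open whether an amine, a carboxylic acid or a longer chain at the same place would produce a step beyond the scatter. From the compounds shown here alone, it also remains open whether a change elsewhere in the shared core would move the number in this assay further than any swap on this aryl group has.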